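Compound 3 to Compound 4: An Exchange on the Aromatic Ring

The source may hold more compounds than are shown below. What is called first, only, known or untested is meant among the compounds shown, and "the series" means these compounds.

In a functional assay on PC-3 cells (Homo sapiens) for cytotoxicity (on this read-out higher numbers stand for an effect only at larger amounts of compound and lower numbers for an effect already at smaller amounts), compound 3 `CCc1ccc(/C=C/C(O)=C2/C(=O)C(C)=C(OC)C(C)(C)C2=O)cc1` gives 15.1 ug/mL. Compound 1 `COC1=C(C)C(=O)/C(=C(O)/C=C/c2cccc(OC)c2)C(=O)C1(C)C` gives 14.3 ug/mL. Going by the values given here, the comparison of these two numbers shows a 1.1-fold higher number from compound 1 to compound 3 (0.02 log units; within the scatter), so compound 3 stands level with the only other exact number. Compound 2 `COC1=C(C)C(=O)/C(=C(O)/C=C/c2ccc(O)cc2)C(=O)C1(C)C` is reported only as a limit of the assay, > 20 ug/mL.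

Compound 4 `COC1=C(C)C(=O)/C(=C(O)/C=C/c2cc(C)cc(C)c2)C(=O)C1(C)C` differs from compound 3 by 3,5-dimethylphenyl in place of 4-ethylphenyl on a double-bonded chain carbon bound to a double-bonded chain carbon. Among the compounds with values here, no measured step makes this exchange directly. The nearest evidence comes from the three steps that alter the same aromatic group, and these show a 1.1-fold higher number from compound 1 to compound 3 (0.02 log units; within the scatter), an at least 1.3-fold higher number from compound 1 to compound 2 (0.14 log units; that floor lies within the scatter) and an at least 1.3-fold lower number from compound 2 to compound 3 (0.12 log units; that floor lies within the scatter). None of them is shown to exceed the scatter, although two of them rest on a limit and give only a floor. Compound 4 is therefore expected to stay close to compound 3 in this assay, with no change beyond the scatter in either direction. The expected outcome is a 1.0-fold lower number from compound 3 to compound 4 (0.00 log units; within the scatter). For compound 4 the estimated value is 15 ug/mL, with an expected range of 8 ug/mL to 24 ug/mL.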

Compound 4, concentration for half-maximal effect: 8.8 ug/mL
Compound 4: the middle estimate sits 1.7-fold (0.23 log units) above what was measured; the measured number falls inside the stated range.
By their numbers in this assay, from the lowest: compounds 4, 1 and 3 (each within the scatter of the next). At a limit, above all of these: compound 2.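

With the same atoms joined differently, the exchange at this place in this assay gives a 1.7-fold lower number from compound 3 to compound 4 (0.23 log units; within the scatter), and 3,5-dimethylphenyl in place of 3-methoxyphenyl gives a 1.6-fold lower number from compound 1 to compound 4 (0.21 log units; within the scatter), so compounds 1, 3 and 4 stand level despite their different aromatic groups. The new result also supplies a step that clears the scatter, which none of the steps among compounds 1, 2 and 3 did: an at least 2.2-fold lower number from compound 2 to compound 4 (0.35 log units; beyond the scatter), so at this place 3,5-dimethylphenyl is separated from 4-hydroxyphenyl. That step is only a floor, since compound 2 is reported as a limit of the assay and not as a number: the limit of > 20 ug/mL in this assay, at which 1 of the 4 values shown sits.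

The compounds shown leave open whether the separation from compound 2 belongs to the hydroxy group itself or would also appear with an amine or a carboxylic acid on the aromatic ring. Going by these compounds alone, they also leave open how far compound 4 can be improved on, since no compound here has a single methyl, a propyl chain or a longer chain on the aromatic ring in its place.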